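The source may report more compounds than this note shows. Statements on the series, on what has been measured and on what is new or still open speak of the compounds shown alone.

Measured compounds:
compound 1 `COc1ccc(NC(=O)CCCCCCCSc2nnc(Cc3nn(C)c(=O)c4ccccc34)n2C)cc1`: 3900 nM
compound 2 `CN(C(=O)CSc1nnc(Cc2nn(C)c(=O)c3ccccc23)n1C)c1ccc(Cl)cc1Cl`: > 30000 nM
compound 3 `Cn1c(Cc2nn(C)c(=O)c3ccccc23)nnc1SCCCCCCCCCCC(=O)Oc1ccc(Cl)cc1Cl`: 8700 nM

In an assay on isolated protein (Mus musculus) for inhibition of IL15-IL15 receptor (Homo sapiens), read by resazurin assay, with stated times of 30 min and 2.5 days (on this read-out lower numbers stand for stronger inhibition and higher numbers for weaker inhibition), compound 1 holds the lowest of the two numbers given; compound 3 gives a number that lies beyond the scatter above it. Compound 2 carries the same (2,4-dichlorophenyl)(methyl)amino group that compound 4 will carry, on a short chain, and in this assay compound 2 reaches only a limit, > 30000 nM, so that no number is known for it. Compound 4 `CN(C(=O)CCCCCCCSc1nnc(Cc2nn(C)c(=O)c3ccccc23)n1C)c1ccc(Cl)cc1Cl` differs from compound 1 in one place: (2,4-dichlorophenyl)(methyl)amino in place of (4-methoxyphenyl)amino on a carbonyl carbon. Going by the values given here, no measured step covers this change. Compound 4 is expected to be weaker, with a step of a 2.6-fold higher number from compound 1 to compound 4 (0.41 log units; beyond the scatter) beyond the scatter, and its estimated value is 10000 nM, between 3500 nM and 30000 nM.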

Compound 4, half-maximal inhibitory concentration: 11900 nM
Compound 4: middle estimate off by 1.2-fold (0.08 log units), on the low side; low and high end bracket the measured number.
By their numbers in this assay, from the lowest: compound 1; then compounds 3 and 4 (each within the scatter of the next). At a limit, above all of these: compound 2.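

Going over to the (2,4-dichlorophenyl)(methyl)amino group gives, in this assay, a 3.1-fold higher number from compound 1 to compound 4 (0.48 log units; beyond the scatter), a modest step. The (2,4-dichlorophenyl)(methyl)amino group therefore still gives a real number on this longer chain. Compound 2, which carries the same group on a short chain, stands only at a limit, > 30000 nM.

The compounds shown leave open how (2,4-dichlorophenyl)amino or (4-methoxyphenyl)(methyl)amino would read, so the methyl and the two chlorines cannot be separated. Also open, from the compounds shown here alone, is how a carboxylic acid in place of this amide would compare.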